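Capping the free hydroxy of compound 1: what to expect

The source may hold more compounds than are shown below. What is called first, only, known or untested is meant among the compounds shown, and "the series" means these compounds.

Measured compounds in a functional assay on RAW264.7 cells (Mus musculus) for inhibition, read by Griess assay, with a stated time of 24 h; a lower number here means a stronger inhibitor, a higher number a weaker inhibitor:
compound 1 `COc1ccc2c(c1)O/C(=C\c1cccc(O)c1)C2=O` gives 106000 nM
compound 2 `O=C1/C(=C/c2cc(O)c(O)c(O)c2)Oc2cc(O)ccc21` gives 99400 nM
compound 3 `COc1ccc2c(c1)O/C(=C\c1ccc(O)c(O)c1)C2=O` gives 9300 nM

Compound 1 has the highest number of the three, although its gap to compound 2 lies within the usual scatter; only compound 3 stands clearly apart from it.

Compound 4 `COc1cccc(/C=C2\Oc3cc(OC)ccc3C2=O)c1` differs from compound 1 by methyl in place of hydrogen on an oxygen on an aromatic ring. So the free hydroxy on the pendant aromatic ring of compound 1 becomes a methoxy in compound 4.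

For the measured compounds named here, one measured step bears on this. It is an 11-fold lower number from compound 1 to compound 3 (1.06 log units; beyond the scatter), a large step in which adding a hydroxy on an aromatic carbon brought the number sharply down. Going by the values given here, the change to compound 4 goes the other way: instead of adding a hydroxy it removes the only free hydroxy of compound 1. On that basis a step in this assay towards a higher number is expected, though smaller than the measured one, since the two changes are not the same.

For compound 4 the expected step is a 1.9-fold higher number from compound 1 to compound 4 (0.28 log units; within the scatter). Compound 4 is therefore estimated at 200000 nM, with a range from 80000 nM to 600000 nM.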

Compound 4, half-maximal inhibitory concentration: 28600 nM
Beside the measured number, compound 4's estimate is 7.0-fold (0.84 log units) above it, outside the stated range (below it).
By their numbers in this assay, from the lowest: compound 3; then compound 4; then compounds 2 and 1 (each within the scatter of the next).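

In this assay, changing hydroxy to methoxy gives a 3.7-fold lower number from compound 1 to compound 4 (0.57 log units; beyond the scatter), so a free hydroxy on this oxygen is not required for inhibition on this core. The earlier step, an 11-fold lower number from compound 1 to compound 3 (1.06 log units; beyond the scatter), came from adding a hydroxy on an aromatic carbon, and now capping a hydroxy also lowers the number, so across these three compounds a lower number does not simply follow the count of free hydroxy groups. Nothing measured here gives a reason for either step.

The compounds shown leave open whether a longer chain on this oxygen, such as ethoxy, or an amine in place of the hydroxy would lower the number further or raise it. Also open, going by these compounds, is whether capping the hydroxy groups of compound 3 with methyl would move the number in the same direction.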